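Acetyl and trifluoroacetyl variants of the amino-substituted core

The compounds below may be only part of what the source reports. "The series", "measured", "known", "first", "only" and "open" are said of these compounds alone.

Compound 1 `CCS(=O)(=O)Nc1cccc2c1CCCC2c1c[nH]cn1` carries an ethylsulfonyl on the ring nitrogen; in an assay on isolated protein for binding affinity to Alpha-1D adrenergic receptor (Rattus norvegicus), read by radioligand binding (on this read-out higher numbers stand for weaker inhibition and lower numbers for stronger inhibition), compound 1 gives 1070 nM. Compound 2 `CC(=O)Nc1cccc2c1CCCC2c1c[nH]cn1` has an acetyl in place of the ethylsulfonyl on that nitrogen. In this assay compound 2 gives < 10000 nM, which is a limit of the assay and not a number. The step that the limit leaves unreadable from compound 1 to compound 2 is therefore not readable in size. Among the compounds with values here, compound 3 `CS(=O)(=O)Nc1ccc(O)c2c1CCCC2c1c[nH]cn1`, with a methylsulfonyl and a hydroxyl on the shared core, in this assay gives < 10000 nM; this too is a limit. the limit of < 10000 nM in this assay, at which 2 of the 3 values shown sit, shows that two of the three values known so far stand at that bound, so compound 2 is placed only by it.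

Compound 4 `O=C(Nc1cccc2c1CCCC2c1c[nH]cn1)C(F)(F)F` differs from compound 2 in one place: trifluoromethyl in place of methyl on a carbonyl carbon. Within the data shown here, no measured step alters the carbonyl substituent, so none bears directly on this change, and the one recorded step has no readable size. Hence no shift beyond the scatter is expected in this assay for the step that the limit leaves unreadable from compound 2 to compound 4. The estimate rests on the bound for compound 2 alone. Compound 4 is expected to give about 4000 nM in this assay, within 800 nM to 20000 nM, with a fair chance that only a limit is reported again.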

Compound 4, inhibition constant: 3310 nM
Estimate against measurement, compound 4: 1.2-fold (0.08 log units) above, within the range that was stated.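

Within the data shown here, compound 4 gives the first readable comparison on this nitrogen between a sulfonyl group and a carbonyl group: in this assay, replacing ethylsulfonyl with (trifluoromethyl)carbonyl gives a 3.1-fold higher number from compound 1 to compound 4 (0.49 log units; beyond the scatter). A carbonyl group on this nitrogen can therefore return a number rather than a limit, although the number is higher than that of the ethylsulfonyl compound 1, and this single pair sets no general order for the two kinds of group. Compound 2 stands only at a limit, < 10000 nM, so the steps from it cannot be read and the change from methyl to trifluoromethyl on the carbonyl carbon has no size: the limit of < 10000 nM in this assay, at which 2 of the 4 values shown sit.

Going by these compounds, it remains open how far the carbonyl substituent matters at all, since a readable value for a longer chain such as propyl, or for a dimethylamino group, on that carbonyl carbon would be needed to give the series a comparison among carbonyl groups. The hydroxyl on the shared core also remains unplaced, as compound 3 differs from the others in more than one place.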